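This account rests on a few compounds, and the source may have more. Where it says the series, first, only, none or still open, it means among the compounds named here.

Measured compounds in this series:

Compound 1, `COc1nc(-c2cc3ccccc3o2)cc(-c2ccc(Cl)cc2)c1C#N`: 286000 nM
Compound 2, `CCOc1nc(-c2cc3ccccc3o2)cc(-c2ccc(Cl)cc2)c1C#N`: 221000 nM
Compound 3, `COc1nc(-c2cc3ccccc3o2)cc(-c2ccc(Br)cc2)c1C#N`: 298000 nM

All three were tested in a functional assay on aorta (strain Wistar) for inhibition, with Thoracic aorta (Rattus norvegicus) as the target; a lower number here means a stronger inhibitor, a higher number a weaker inhibitor. Compound 2 has the lowest of the three numbers, but its separation from the others is small: the step of a 1.3-fold lower number from compound 1 to compound 2 (0.11 log units; within the scatter) lies within the scatter, and compound 3 stands only slightly further away from compound 2 than compound 1 does. The three values therefore belong to one cluster of weak inhibitors, and compound 2 cannot be called the strongest among them.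

The compound under consideration, compound 4, has the structure `CCOc1nc(-c2cc3ccccc3o2)cc(-c2ccc(F)cc2)c1C#N`. It differs from compound 2 by fluoro in place of chloro on an aromatic carbon.

Among the measured compounds shown here, no measured step swaps chloro for fluoro at this position. For the measured compounds named here, the nearest precedent is the halogen exchange a 1.0-fold higher number from compound 1 to compound 3 (0.02 log units; within the scatter), which changed nothing beyond the scatter; the ethoxy-for-methoxy step a 1.3-fold lower number from compound 1 to compound 2 (0.11 log units; within the scatter) was likewise flat. On this evidence the expected step of a 1.1-fold higher number from compound 2 to compound 4 (0.05 log units; within the scatter) in this assay is small, with no direction that can be read out of the data beyond the scatter.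

Compound 4 is therefore estimated at 250000 nM in this assay, with a range from 120000 nM to 520000 nM.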

Compound 4, half-maximal inhibitory concentration: 396000 nM
Compound 4: the middle estimate sits 1.6-fold (0.20 log units) below what was measured, within the range that was stated.
By their numbers in this assay, from the lowest: compounds 2, 1, 3 and 4 (each within the scatter of the next).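

With the ethoxy group held in place, the exchange of 4-chlorophenyl for 4-fluorophenyl in this assay gives a 1.8-fold higher number from compound 2 to compound 4 (0.25 log units; within the scatter) and so stays inside the scatter, although it is the widest single step printed for this series. Taken with a 1.0-fold higher number from compound 1 to compound 3 (0.02 log units; within the scatter) on the methoxy side, it means that chloro, bromo and fluoro have now each stood on this aromatic carbon, para to a large group, without any step reaching beyond the scatter. Among the compounds shown here, the fluoro compound therefore joins the same cluster of weak inhibitors, and the series gives no sign that this position responds to one halogen being exchanged for another, though only two such exchanges can be read, and they sit on different compounds.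

No measurement is available that bears on this result.

On these data alone, what stays open is whether a group other than a halogen at this position, such as an amine or a carboxylic acid, would move the number beyond the scatter. The same question stands for a longer chain in place of the ethoxy group.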